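The compounds below may be only part of what the source reports. "The series", "measured", "known", "first", "only" and "open" are said of these compounds alone.

Compound 2, with the structure `CC(=O)c1ccc(-c2cn3ccnc3c(-c3ccc4ncn(C5CCCCC5)c4c3)n2)cc1`, is the lower of the two compounds measured in a functional assay on LOX IMVI cells (Homo sapiens) for inhibition, read by sulforhodamine B assay, with a stated time of 48 h, tested at 10 uM (on this read-out lower numbers stand for less inhibition and higher numbers for more inhibition at the one concentration tested (going by the name of the read-out)), where compound 2 gives 14.5%. Its nearest neighbour is compound 1, with the structure `Brc1cn2ccnc2c(-c2ccc3ncn(C4CCCCC4)c3c2)n1`, which in this assay gives 15.2%; the step of a number 0.7 percentage points lower from compound 1 to compound 2 (within the scatter) lies within the scatter, so the two numbers cannot be told apart. Compound 3, with the structure `Clc1ccc(-c2cn3ccnc3c(-c3ccc4ncn(C5CCCCC5)c4c3)n2)cc1`, has not yet been measured in this assay. It differs from compound 2 in one place: chloro in place of acetyl on an aromatic carbon. Among the measured compounds shown here, no measured step covers this exact exchange; the only step recorded, from compound 1 to compound 2, exchanged bromo for 4-acetylphenyl and stayed within the scatter, which shows that the aromatic ring bearing the acetyl could be added without a change beyond the scatter. On that basis the exchange of acetyl for chloro on that ring is expected to give a step of a number 0.5 percentage points higher from compound 2 to compound 3 (within the scatter) of no size beyond the scatter. Compound 3 is therefore estimated at 15%, within a range from 4% to 32%.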

Compound 3, a percentage reported as inhibition, at one concentration (the size of the read-out at that concentration, not a potency): 14.8%
For compound 3 the middle estimate is 0.2 percentage points above the measured one; the range from low to high includes it.
By their numbers in this assay, from the lowest: compounds 2, 3 and 1 (each within the scatter of the next).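

In this assay, the step of a number 0.3 percentage points higher from compound 2 to compound 3 (within the scatter) shows that on the six-membered aromatic ring, para to a large group, chloro with its single heavy atom can take the place of acetyl, with its three heavy atoms, carbonyl and hydrogen-bond acceptor, while the number stays within the scatter. The step of a number 0.4 percentage points lower from compound 1 to compound 3 (within the scatter) adds 4-chlorophenyl as a second aryl group that, like 4-acetylphenyl, cannot be told apart from the bromo of compound 1 on these numbers, so none of the three groups shown separates from the others at this place. Nothing measured alongside these numbers bears on this result.

The compounds shown leave open whether an amine or a carboxylic acid at the same place on that ring would give a number beyond the scatter. As far as these compounds go, they also all share the rest of the structure and were read at one concentration, so what a change elsewhere on the core would do, and how these numbers would run across concentrations, remains open.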